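A few compounds are considered here, and "the series" means these few. Any claim that something is new, unique, unknown or untested is made for them only; others in the source may bear on it.

In a functional assay on HL-60 cells (Homo sapiens) for antiproliferative activity, read by XTT assay, with a stated time of 72 h (a higher number here means a weaker inhibitor, a lower number a stronger inhibitor), the measured compounds are:

Compound 1 `C#Cc1cn([C@@H]2O[C@H](CO)[C@@H](O)[C@H]2O)c2ncnc(OC)c12`: 190 nM
Compound 2 `C#Cc1cn([C@@H]2O[C@H](CO)[C@@H](O)[C@H]2O)c2ncnc(NC)c12`: 9060 nM
Compound 3 `Cc1ncnc2c1c(-c1ccoc1)cn2[C@@H]1O[C@H](CO)[C@@H](O)[C@H]1O`: > 15000 nM, a limit and not a number

Compound 3 has no exact value, only a limit: the limit of > 15000 nM in this assay, at which 1 of the 3 values shown sits. Putting ethynyl in place of furan-3-yl on an aromatic carbon gives compound 4 `C#Cc1cn([C@@H]2O[C@H](CO)[C@@H](O)[C@H]2O)c2ncnc(C)c12`: ethynyl in place of furan-3-yl on an aromatic carbon.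

Among the compounds with values here, no measured step makes this exact swap, so the evidence is indirect. Compound 1 and compound 2 both carry ethynyl, and both give numbers in this assay. Within the data shown here, the one measured step, a 48-fold higher number from compound 1 to compound 2 (1.68 log units; beyond the scatter), replaces methoxy with methylamino on an aromatic carbon. It shows that ethynyl compounds can differ widely, so it widens the uncertainty without setting a direction for compound 4.

Compound 4 is therefore expected to give a lower number than compound 3, a stronger result and a move beyond the scatter, landing within the span set by compound 1 at 190 nM and compound 2 at 9060 nM. The expected move is an at least 16-fold lower number from compound 3 to compound 4 (1.22 log units; beyond the scatter). For compound 4, the estimated value is 900 nM, with an expected range of 100 nM to 8000 nM.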

Compound 4, half-maximal inhibitory concentration: 1110 nM
For compound 4 the middle estimate is 1.2-fold (0.09 log units) below the measured one; measured number inside the range.
By their numbers in this assay, from the lowest: compound 1; then compound 4; then compound 2. At a limit, above all of these: compound 3.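

Compound 3 gives a limit and not a number: the limit of > 15000 nM in this assay, at which 1 of the 4 values shown sits. Within the data shown here, on this aromatic carbon of the five-membered ring, ethynyl in place of furan-3-yl brings an at least 13-fold lower number from compound 3 to compound 4 (1.13 log units; beyond the scatter), the first direct reading of this swap, and its size is a minimum and not an exact figure. With ethynyl held fixed, the group on the other aromatic carbon also matters: methyl in place of methylamino gives an 8.2-fold lower number from compound 2 to compound 4 (0.91 log units; beyond the scatter), whereas methyl in place of methoxy gives a 5.8-fold higher number from compound 1 to compound 4 (0.77 log units; beyond the scatter), which places methyl between the other two groups.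

Going by these compounds, it remains open how a nitrile or a longer alkyne chain would behave on the ethynyl-bearing carbon. On these data alone, the swap from furan-3-yl to ethynyl is also read only with methyl on the core, so its size with methoxy or methylamino there is unknown.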